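Methylation of a phenol in a pyrazole series

This account rests on a few compounds, and the source may have more. Where it says the series, first, only, none or still open, it means among the compounds named here.

Measured so far:
compound 1, `COc1cc(Cl)cc(-c2nn(-c3cccc(NC(=O)c4cccc(C(F)(F)F)c4)c3)cc2-c2ccncc2)c1`, 66.6%
compound 2, `O=C(Nc1cccc(-n2cc(-c3ccncc3)c(-c3cc(O)cc(Cl)c3)n2)c1)c1cc(C(F)(F)F)cc(C(F)(F)F)c1`, 55.2%

Of the compounds shown here, two have been measured in a functional assay on 786-0 cells (Homo sapiens) for inhibition, read by sulforhodamine B assay, with a stated time of 48 h, tested at 10 uM; a lower number here means a stronger effect, a higher number a weaker effect of the compound at the concentration tested. Among the compounds with values here, compound 2 stands lowest of the two numbers, and its nearest neighbour, compound 1, gives a number that is higher by a margin beyond the scatter; no step between the two is defined here, as they differ in more than one place.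

Compound 3, `COc1cc(Cl)cc(-c2nn(-c3cccc(NC(=O)c4cc(C(F)(F)F)cc(C(F)(F)F)c4)c3)cc2-c2ccncc2)c1`, is not yet measured. It differs from compound 2 in one place: methyl in place of hydrogen on an oxygen on an aromatic ring. Within the data shown here, compound 1 also carries the methoxy group, but the two are not a one-step pair, so the only guide is the single value of compound 2.

Among the measured compounds shown here, with no measured step to build on, the change is expected to move this assay only modestly, if at all; a small shift towards a higher number is thought somewhat more likely than a drop, but a step within the scatter would not surprise. For compound 3 the estimate is 60%, with a range from 45% to 75%, meaning an expected step of a number 4.8 percentage points higher from compound 2 to compound 3 (within the scatter).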

Compound 3, a percentage reported as activity, at one concentration (the size of the read-out at that concentration, not a potency): 80.2%
Compound 3: middle estimate off by 20.2 percentage points, on the low side; the whole stated range lies below it.
By their numbers in this assay, from the lowest: compound 2; then compound 1; then compound 3.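

In this assay, the change from hydroxy to methoxy on the 3-chloro-5-hydroxyphenyl group gives a number 25 percentage points higher from compound 2 to compound 3 (beyond the scatter), which shows that this oxygen is not a silent place in the series, at least in this one pair: the free hydroxy goes with the stronger effect at the concentration tested. Compound 3 also provides a second comparison, in which trifluoromethyl in place of hydrogen on an aromatic carbon, with the methoxy group kept, gives a number 13.6 percentage points higher from compound 1 to compound 3 (beyond the scatter), so the added trifluoromethyl goes with a weaker effect in this methoxy setting. No measurement shown here explains either step.

The compounds shown leave open whether the hydroxy to methoxy step keeps its size with a single trifluoromethyl group, and whether an amine or an ethoxy group at this place would read like the hydroxy or like the methoxy. Each number is also a read-out at one concentration, so it speaks only of a stronger or weaker effect at that concentration.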